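Working notes: acyl change from compound 2 to compound 3

The source may report more compounds than this note shows. Statements on the series, on what has been measured and on what is new or still open speak of the compounds shown alone.

Measured so far:
compound 1 `CCCCCCCCNC(=O)[C@@H](NC(=O)c1ccccc1)[C@@H](C)O` gives 112000 nM in a functional assay on SiHa cells (Homo sapiens) for cytotoxicity, read by MTT assay, with a stated time of 48 h; on this read-out lower numbers stand for stronger inhibition and higher numbers for weaker inhibition.
compound 2 `CCCCCCCCCCCCCCNC(=O)[C@@H](NC(=O)c1ccccc1)[C@@H](C)O` gives > 200000 nM in this assay.

Compound 2 stands at the top of the numbers shown. Its value is a limit of this assay and not a number; it sits at the limit of > 200000 nM in this assay, at which 1 of the 2 values shown sits. Among the compounds with values here, the one measured step, an at least 1.7-fold higher number from compound 1 to compound 2 (0.25 log units; that floor lies within the scatter), concerns only the length of the chain on the amide-type nitrogen and ends at that limit, so it gives no numerical reach beyond the floor it states.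

Compound 3 `CCCCCCCCCCCCCCNC(=O)[C@@H](NC(=O)/C=C/c1ccccc1)[C@@H](C)O` differs from compound 2 in the acyl part: 2-phenylethenyl in place of phenyl on a carbonyl carbon. Within the data shown here, no measured step touches this position, so nothing among the measured compounds bears on the change from phenyl to 2-phenylethenyl, and no direction can be taken from the data. With compound 2 already at the limit, compound 3 is expected to sit at or near that limit as well, and the expected step of a number no higher from compound 2 to compound 3 (the limit leaves the size open) is none beyond the scatter. Compound 3 is thus estimated at 200000 nM in this assay, with a range from 60000 nM to 600000 nM.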

Compound 3, half-maximal inhibitory concentration: 35800 nM
Compound 3: middle estimate off by 5.6-fold (0.75 log units), on the high side; measured number below the stated range.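

In this assay, 2-phenylethenyl in place of phenyl on a carbonyl carbon gives an at least 5.5-fold lower number from compound 2 to compound 3 (0.74 log units; beyond the scatter), so the acyl part is a position that can move this read-out, even with the long chain on the amide-type nitrogen kept. Within the data shown here, the only earlier step, an at least 1.7-fold higher number from compound 1 to compound 2 (0.25 log units; that floor lies within the scatter), concerned that chain alone. Compound 3 gives 35800 nM, a measured number. The new step is only a floor, and its full size stays open because compound 2 stands at a limit of the assay, not at a number: the limit of > 200000 nM in this assay, at which 1 of the 3 values shown sits.

The change brings in a larger group and a double bond outside aromatic rings together, and the compounds shown do not separate the two; a saturated 2-phenylethyl group on the same carbonyl carbon would bear on that question. Also open, going by these compounds, are whether the same acyl change holds on the shorter chain of compound 1 and how an amine or a carboxylic acid on the aromatic ring of the 2-phenylethenyl group would read.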